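Swapping the charged head group on a long chain

The source may report more compounds than this note shows. Statements on the series, on what has been measured and on what is new or still open speak of the compounds shown alone.

Measured compounds:
- Compound 1, `Cc1cc(OCCCCCCC[N+]23CCN(CC2)CC3)cc(-n2cc(C(=O)Nc3cc(F)cc(F)c3)c(=O)c3ccc(N(C)C)nc32)c1`: 5.52%
- Compound 2, `CC[N+]1(CCCCCCCOc2cc(C)cc(-n3cc(C(=O)Nc4cc(F)cc(F)c4)c(=O)c4ccc(N(C)C)nc43)c2)CCCC1`: 73.2%

In an assay on LX2 cells for inhibition of COL1A1 promoter (Homo sapiens), read by a luciferase reporter, with a stated time of 24 h, tested at 50 uM (a lower number here means a weaker effect, a higher number a stronger effect of the compound at the concentration tested), compound 2 gives 73.2%, the higher of the two numbers, and compound 1 gives 5.52%. For the measured compounds named here, the only measured step, a number 67.7 percentage points higher from compound 1 to compound 2 (beyond the scatter), shows that the charged group at the end of the chain decides how much of the effect is seen.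

Compound 3, `Cc1cc(OCCCCCCC[N+](C)(C)C2CCCCC2)cc(-n2cc(C(=O)Nc3cc(F)cc(F)c3)c(=O)c3ccc(N(C)C)nc32)c1`, has not yet been measured. It differs from compound 2 in the same place: a group of 9 heavy atoms (8 carbon, 1 nitrogen; one six-membered non-aromatic ring of carbon only) in place of a group of 7 heavy atoms (6 carbon, 1 nitrogen; one five-membered non-aromatic ring with 1 hetero atom), on a saturated chain carbon, seven bonds along the chain from an oxygen on an aromatic ring. Going by the values given here, the net charge of the head group stays the same, as does its position on the chain, so the change is smaller in kind than the one from compound 1 to compound 2, which exchanged two rings for one. Among the compounds with values here, no measured step tells how two single-ring charged groups compare, so a modest step in either direction in this assay is expected, with compound 2 as the anchor. The expected step is a number 11.2 percentage points lower from compound 2 to compound 3 (beyond the scatter). Compound 3 is therefore estimated at 62%, within a range from 30% to 85%.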

Compound 3, a percentage reported as inhibition, at one concentration (the size of the read-out at that concentration, not a potency): 89.1%
Compound 3: the middle estimate sits 27.1 percentage points below what was measured; the measured number lies above the stated range.
By their numbers in this assay, from the lowest: compound 1; then compound 2; then compound 3.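

In this assay, the two single-ring charged groups do not behave alike: a number 15.9 percentage points higher from compound 2 to compound 3 (beyond the scatter) is a modest gain when the head group with a six-membered ring of carbon only replaces the one with a five-membered ring containing a hetero atom. For the compounds shown here, this is the first comparison at this place on the chain that does not involve the two-ring head group of compound 1, and a number 83.6 percentage points higher from compound 1 to compound 3 (beyond the scatter) shows a large gap between that group and the new one, on the same scale as the gap already seen with compound 2. Because neither compound 2 nor compound 3 differs in net charge or in its count of hydrogen-bond donors and acceptors at this head group, those counts alone cannot separate them.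

Nothing shown here explains why these head groups give different read-outs. Still open, on these data alone, is how a six-membered ring containing nitrogen, such as a piperidine ring, or an uncharged tertiary amine at the same chain position would compare, and each number here describes the size of the effect at one concentration, not a potency.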